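Naphthyl to bromophenyl sulfonate swap on a hydroxamate scaffold

The compounds below may be only part of what the source reports. "The series", "measured", "known", "first", "only" and "open" are said of these compounds alone.

Compound 1 `O=C(O)CCCCCCC(=O)Nc1ccc(C2=C(c3ccc(O)cc3)C3CC(S(=O)(=O)Oc4cccc5ccccc45)C2O3)cc1` — an assay on isolated protein for inhibition of protein deacetylase HDAC6 (Homo sapiens), read by fluorescence, with a stated time of 15 min; a lower number here means a stronger inhibitor, a higher number a weaker inhibitor: "not active" (no number reported)
Compound 2 `O=C(CCCCCCC(=O)Nc1ccc(C2=C(c3ccc(O)cc3)C3CC(S(=O)(=O)Oc4cccc5ccccc45)C2O3)cc1)NO` — this assay: 30 nM

Compound 2 gives the only number shown; compound 1, which carries a carboxylic acid in place of the hydroxamic acid, is reported without a number. Compound 3 `O=C(CCCCCCC(=O)Nc1ccc(C2=C(c3ccc(O)cc3)C3CC(S(=O)(=O)Oc4ccc(Br)cc4)C2O3)cc1)NO` differs from compound 2 by 4-bromophenyl in place of naphthalen-1-yl on an oxygen, a change far from the hydroxamic acid. Going by the values given here, no measured step covers such a swap, so no movement beyond the usual scatter is expected in this assay. Compound 3 is therefore estimated at 35 nM, with a range of 12 nM to 110 nM, corresponding to an expected step of a 1.2-fold higher number from compound 2 to compound 3 (0.07 log units; within the scatter).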

Compound 3, half-maximal inhibitory concentration: 230 nM
Compound 3: the middle estimate sits 6.6-fold (0.82 log units) below what was measured; the measured number lies above the stated range.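

The group on the oxygen bonded to the sulfonyl sulfur matters in this assay: 4-bromophenyl in place of naphthalen-1-yl gives a 7.7-fold higher number from compound 2 to compound 3 (0.88 log units; beyond the scatter). Compound 1 and compound 2 had shown only the difference between a carboxylic acid and a hydroxamic acid, so this is the first sign that this position also counts. Nothing available explains the size of the step. Going by these compounds, whether the step follows the loss of one aromatic ring or the arrival of bromine stays open, and an unsubstituted phenyl on the same oxygen would help separate the two.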